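This account rests on a few compounds, and the source may have more. Where it says the series, first, only, none or still open, it means among the compounds named here.

Of the compounds shown here, three sharing one core have been measured in an ADME assay on MT2 cells (Homo sapiens) for cytotoxicity, read by XTT assay, with a stated time of 4 days; a lower number here means that less compound is tolerated, a higher number that more compound is tolerated. Compound 1 `O=C(O)c1ccc(-c2noc(CCl)n2)cc1` gives 64000 nM, compound 2 `COC(=O)c1ccc(-c2noc(CSC#N)n2)cc1` gives 43700 nM, and compound 3 `COC(=O)c1ccc(-c2noc(CBr)n2)cc1` gives 32700 nM. Compound 2 stands second highest of the three, with compound 3 nearest and compound 1 furthest, and both gaps lie within the scatter. For the measured compounds named here, the only pair that differs in a single place is compound 2 and compound 3, and that step, a 1.3-fold lower number from compound 2 to compound 3 (0.13 log units; within the scatter), is within the scatter as well.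

Compound 4 `N#CSCc1nc(-c2ccc(C(=O)O)cc2)no1` is now to be measured in this assay. It differs from compound 2 in one place: hydrogen in place of methyl on an oxygen next to a carbonyl group. Going by the values given here, no measured pair isolates this change. Compound 1 carries the carboxy group and gives 64000 nM, whereas compound 3 carries the methoxycarbonyl group and gives 32700 nM, but these two also differ at the saturated chain carbon, so their gap, itself within the scatter, cannot be assigned to the ester-to-acid change alone.

Compound 4 is therefore expected to give roughly 55000 nM, within a range from 25000 nM to 120000 nM. Compound 4 is expected to show a step of a 1.3-fold higher number from compound 2 to compound 4 (0.10 log units; within the scatter), which would stay within the scatter.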

Compound 4, half-maximal cytotoxic concentration: 383000 nM
For compound 4 the middle estimate is 7.0-fold (0.84 log units) below the measured one; measured number above the stated range.
By their numbers in this assay, from the lowest: compounds 3, 2 and 1 (each within the scatter of the next); then compound 4.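

In this assay, for the compounds shown here, the change from methoxycarbonyl to carboxy now has a step of its own, with the cyanosulfanyl group held in place: an 8.8-fold higher number from compound 2 to compound 4 (0.94 log units; beyond the scatter) is read here, and it lies beyond the scatter, unlike the one earlier step. The saturated chain carbon also proves able to shift this number, since with the carboxy group held in place, cyanosulfanyl instead of chloro gives a 6.0-fold higher number from compound 1 to compound 4 (0.78 log units; beyond the scatter) and this too lies beyond the scatter, whereas a 1.3-fold lower number from compound 2 to compound 3 (0.13 log units; within the scatter) did not show this with the methoxycarbonyl group held in place. Both steps end at compound 4, so the high number is tied so far to carboxy and cyanosulfanyl standing together, and nothing available here accounts for either step.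

The compounds shown leave open whether the change from methoxycarbonyl to carboxy gives a step of similar size when the chain carbon carries chloro or bromo instead of cyanosulfanyl. They also leave open what an amide in place of the carboxy group, or a longer chain carrying the cyanosulfanyl group, would do to this number.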